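The source may report more compounds than this note shows. Statements on the series, on what has been measured and on what is new or still open speak of the compounds shown alone.

In a functional assay on MDA-MB-231 cells (Homo sapiens) for inhibition, read by MTT assay (a higher number here means a weaker inhibitor of growth, a lower number a stronger inhibitor of growth), compound 1 (`CC1=C(/C=C/C(C)=C/C=C/C(C)=C\C(=O)Nc2cccc(F)c2)C(C)(C)CCC1n1ccnc1`) gives 8510 nM. Compound 2 (`CC1=C(/C=C/C(C)=C/C=C/C(C)=C\C(=O)NCc2ccc(O)cc2)C(C)(C)CC=C1c1cncnc1`) gives 11500 nM, which lies within the scatter of the value for compound 1, so the two cannot be ranked. Compound 3 (`CC1=C(/C=C/C(C)=C/C=C/C(C)=C\C(=O)Nc2ccccc2)C(C)(C)CC=C1c1cncnc1`) gives 26900 nM, a higher number than compound 1 by a margin beyond the scatter.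

Compound 4 (`CC1=C(/C=C/C(C)=C/C=C/C(C)=C\C(=O)NCc2ccccc2)C(C)(C)CCC1n1ccnc1`) has not yet been measured. It keeps the core of compound 1 and differs only in the group on the amide: benzyl in place of 3-fluorophenyl on an amide-type nitrogen.

Among the measured compounds shown here, one measured step bears on this change: a 2.3-fold higher number from compound 2 to compound 3 (0.37 log units; beyond the scatter), with phenyl in place of 4-hydroxybenzyl on an amide-type nitrogen. Read in reverse, this modest step favours the benzyl-type group with a lower number. It is only a loose guide, however, since compound 2 and compound 3 have a different core from compound 1 and the groups involved are not the same.

A small move towards a lower number is therefore expected, possibly no larger than the scatter, and the estimated step is a 1.4-fold lower number from compound 1 to compound 4 (0.15 log units; within the scatter). For compound 4 the expected value is 6000 nM, with an estimated range of 2500 nM to 14000 nM.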

Compound 4, concentration for 50% growth inhibition: 5880 nM
For compound 4 the middle estimate is 1.0-fold (0.01 log units) above the measured one; low and high end bracket the measured number.
By their numbers in this assay, from the lowest: compounds 4, 1 and 2 (each within the scatter of the next); then compound 3.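

In this assay, the exchange of 3-fluorophenyl for benzyl on the amide-type nitrogen, made on the core of compound 1, gives a 1.4-fold lower number from compound 1 to compound 4 (0.16 log units; within the scatter), so the two groups cannot be ranked on this core. Among the compounds shown here, the only earlier step at this nitrogen, a 2.3-fold higher number from compound 2 to compound 3 (0.37 log units; beyond the scatter), lay beyond the scatter, but it was read on a different core and with different groups; the pair of compound 1 and compound 4 shows no difference beyond the scatter. No measurement is available here that would account for this result.

The step also combines two differences, the loss of the fluorine and the gain of a carbon in the benzyl group, and the compounds shown do not separate them, since unsubstituted phenyl is not shown on the core of compound 1. They also leave open how this position responds to groups of another kind, such as a longer chain like 2-phenylethyl, or an amine or a carboxylic acid carried on the benzyl ring.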